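The source may report more compounds than this note shows. Statements on the series, on what has been measured and on what is new or still open speak of the compounds shown alone.

Compound 3 `CCCCCCCCCO[C@@H]1[C@@H](N)[C@@H](OCC(O)CNCCN)O[C@H](CN)[C@H]1OCCCCCCCCC` gives 87.5% in a toxicity assay on the whole organism (J774 cells) for cytotoxicity, with Mus musculus as the target, read by MTT assay, with a stated time of 24 h, tested at 10 uM (on this read-out higher numbers stand for a weaker effect at the one concentration tested and lower numbers for a stronger effect), the second highest of three numbers. Compound 1 `CCCCCCCCCO[C@@H]1[C@@H](N)[C@@H](OCC(O)CO)O[C@H](CN)[C@H]1OCCCCCCCCC` gives 89.7% in this assay, and the two lie within the scatter, as a number 2.2 percentage points lower from compound 1 to compound 3 (within the scatter) shows. Compound 2 `CCCCCCCCCO[C@@H]1[C@@H](N)[C@@H](OC[C@H](O)CN=[N+]=[N-])O[C@H](CN)[C@H]1OCCCCCCCCC` gives 62.2% in this assay, and the step of a number 25.3 percentage points higher from compound 2 to compound 3 (beyond the scatter) went beyond the scatter. Compound 4 `CCCCCCCCCO[C@@H]1[C@@H](N)[C@@H](OC[C@@H](O)CN)O[C@H](CN)[C@H]1OCCCCCCCCC` differs from compound 3 in one place: 2-amino-1-hydroxyethyl in place of 2-((2-aminoethyl)amino)-1-hydroxyethyl on a saturated chain carbon bound to an oxygen on a saturated carbon. The step that bears on this change is a number 2.2 percentage points lower from compound 1 to compound 3 (within the scatter), where (2-aminoethyl)amino in place of hydroxy moved nothing beyond the scatter; the step of a number 27.5 percentage points lower from compound 1 to compound 2 (beyond the scatter) concerns the 2-azido-1-hydroxyethyl group and does not bear on it. Compound 4 is therefore expected to show a number 1.5 percentage points lower from compound 3 to compound 4 (within the scatter), an estimated 86% in this assay, with a range from 72% to 96%.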

Compound 4, a percentage reported as activity, at one concentration (the size of the read-out at that concentration, not a potency): 85.1%
Beside the measured number, compound 4's estimate is 0.9 percentage points above it, and the stated range covers the measured number.
By their numbers in this assay, from the lowest: compound 2; then compounds 4, 3 and 1 (each within the scatter of the next).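

In this assay the 2-amino-1-hydroxyethyl group cannot be told apart from the longer amine, with a number 2.4 percentage points lower from compound 3 to compound 4 (within the scatter) as the step, or from the 1,2-dihydroxyethyl group, with a number 4.6 percentage points lower from compound 1 to compound 4 (within the scatter) as the step. The single primary amine thus sides with these two groups and not with the azide, as a number 22.9 percentage points higher from compound 2 to compound 4 (beyond the scatter) shows for the exchange of azide for amine at this place. Nothing available here explains this result. On these data alone, what a carboxylic acid or a guanidine at this place would give remains open.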